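Working notes: the step from compound 3 to compound 4

The compounds below may be only part of what the source reports. "The series", "measured", "known", "first", "only" and "open" are said of these compounds alone.

Measured in a toxicity assay on MT2 cells (Homo sapiens) for cytotoxicity, read by XTT assay, with a stated time of 4 days (on this read-out lower numbers stand for higher toxicity in this test and higher numbers for lower toxicity in this test), each entry a limit and not a number:
- compound 1 `COc1cccc(CCOc2ccc(-c3c(C)nc(C)c([C@H](OC(C)(C)C)C(=O)O)c3N3CCC(C)(C)CC3)cc2)c1` gives >= 33500 nM
- compound 2 `Cc1nc(C)c([C@H](OC(C)(C)C)C(=O)O)c(N2CCC(C)(C)CC2)c1-c1ccc(OCCc2ccc(F)cc2F)cc1` gives >= 33500 nM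
- compound 3 `Cc1nc(C)c([C@H](OC(C)(C)C)C(=O)O)c(N2CCC(C)(C)CC2)c1-c1ccc(OCCc2cc(F)ccc2F)cc1` gives >= 33500 nM

Compound 3 has only a limit (>= 33500 nM) and no number. All three compounds sit there, as the limit of >= 33500 nM in this assay, at which 3 of the 3 values shown sit, shows.

Compound 4 `Cc1nc(C)c([C@H](OC(C)(C)C)C(=O)O)c(N2CCC(C)(C)CC2)c1-c1ccc(OCCc2cc(F)c(F)cc2F)cc1` differs from compound 3 as follows: fluoro in place of hydrogen on an aromatic carbon.

The nearest measured changes are a step that the two limits leave unreadable from compound 1 to compound 3 and a step that the two limits leave unreadable from compound 2 to compound 3, along with a step that the two limits leave unreadable from compound 1 to compound 2. None has a readable size, so none supplies a size or direction to carry over.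

No shift beyond the scatter is expected in this assay, and the expected size is a step that the limit leaves unreadable from compound 3 to compound 4 with no readable direction. Compound 4 is estimated at 35000 nM, with an expected range from 20000 nM to 60000 nM, and will most likely be reported as a limit again.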

Compound 4, half-maximal cytotoxic concentration: >= 33500 nM
Compound 4: no number, only a limit (the forecaster's own chance of this, stated with the estimate: 88%); the middle value lies beyond the limit too.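

Compound 1, compound 2, compound 3 and compound 4 all give only a limit in this assay, so no step among them can be read: the limit of >= 33500 nM in this assay, at which 4 of the 4 values shown sit.

The compounds shown leave open at what concentration any of them turns cytotoxic, and whether fluoro in place of hydrogen changes that concentration.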